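From an Acid Ether to a Dimethylamide Alkene

The source may report more compounds than this note shows. Statements on the series, on what has been measured and on what is new or still open speak of the compounds shown alone.

Measured compounds:
- compound 1, `O=C(COc1ccncc1-c1ccc2ccccc2c1)N1CCOCC1`: "not determined" (no result reported)
- compound 2, `O=C(O)COc1ccncc1-c1ccc2ccccc2c1`: "not determined" (no result reported)
- compound 3, `Cn1ncc2cc(-c3cnccc3/C=C/C(=O)N3CCOCC3)ccc21`: 356 nM

Only compound 3 carries a number in an assay on a protein complex for inhibition of CDK8/Cyclin C (Homo sapiens), with a stated time of 1 h; on this read-out higher numbers stand for weaker inhibition and lower numbers for stronger inhibition; it gives 356 nM. Compound 2 stands without a value, reported as "not determined" (no result reported), and compound 1 is in the same position with "not determined" (no result reported), so there is nothing to rank compound 2 against on the numbers shown.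

The step goes from compound 2 to compound 4, `CN(C)C(=O)/C=C/c1ccncc1-c1ccc2ccccc2c1`. The change is 2-(dimethylcarbamoyl)ethenyl in place of carboxymethoxy on an aromatic carbon. The group that leaves is the carboxymethoxy, which brings a hydrogen-bond donor; the group that enters is the 2-(dimethylcarbamoyl)ethenyl, with no donor and one acceptor, sitting ortho to a large group and opposite the ring nitrogen.

Because compound 2 reads "not determined" (no result reported), the size and direction of this step in this assay cannot be read from the data; nothing can be said of it beyond the fact that one side is blank. Among the measured compounds shown here, the only guide is compound 3, which carries a related ethenyl amide and gives 356 nM. On that basis compound 4 is expected to land near 600 nM, with a range from 100 nM to 4000 nM.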

Compound 4, half-maximal inhibitory concentration: 30.1 nM
Compound 4: the middle estimate sits 20-fold (1.30 log units) above what was measured, outside the stated range (below it).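

Among the compounds shown here, compound 4 gives 30.1 nM but compound 2 has no single number to set against it, so no step between these two compounds can be read. The compounds shown leave open how the 2-(dimethylcarbamoyl)ethenyl group compares with the carboxymethoxy group on the same core. No supporting finding is available to explain the value of compound 4.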